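A few compounds are considered here, and "the series" means these few. Any claim that something is new, unique, unknown or untested is made for them only; others in the source may bear on it.

Two members of this series have been examined in an ADME assay on CEM174 cells (Homo sapiens) for cytotoxicity; a higher number here means that more compound is tolerated, a lower number that less compound is tolerated. Compound 1 `Cc1ccc(-c2cnnc(NCc3cc(-c4ccccc4)[nH]n3)n2)cc1` gives > 10000 nM, which is a limit of the assay rather than a number. Compound 2 `Cc1ccccc1-c1ccnc(NCc2cc(-c3ccccc3)[nH]n2)c1` likewise gives > 10000 nM, again only a limit. Within the data shown here, compound 2 thus stands at the limit of > 10000 nM in this assay, at which 2 of the 2 values shown sit, with no measured number to place it against compound 1, and no step between measured compounds can be drawn from the series. Compound 3 `Cc1cc(C#N)ccc1-c1ccnc(NCc2cc(-c3ccccc3)[nH]n2)c1` differs from compound 2 by cyano in place of hydrogen on an aromatic carbon, in words: cyano in place of hydrogen on an aromatic carbon. Among the measured compounds shown here, with no measured step to lean on, the expected change in this assay is none beyond the scatter, and the most probable outcome is that compound 3 again reports only a limit, because compound 2 sits at the limit of > 10000 nM in this assay, at which 2 of the 2 values shown sit. Compound 3 is therefore estimated at 12000 nM, in a range from 4000 nM to 35000 nM. The expected step is a step that the limit leaves unreadable from compound 2 to compound 3, within the scatter in this assay.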

Compound 3, half-maximal cytotoxic concentration: > 10000 nM
Compound 3: a limit, no number; the forecaster's own chance of this, stated with the estimate: 75%; the middle value does not contradict the limit.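

Compound 2 and compound 3 both report only a limit in this assay, so no step can be read for cyano in place of hydrogen on an aromatic carbon. The compounds shown leave open where any of them would fall as an actual number in this assay, and whether that change shifts it at all.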